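Replacing the aryl group of compound 3

The source may report more compounds than this note shows. Statements on the series, on what has been measured and on what is new or still open speak of the compounds shown alone.

Compound 1 `O=C(CCCCCCc1nc(-c2cccc([N+](=O)[O-])c2)no1)NO`: 1160 nM
Compound 2 `Nc1ccccc1NC(=O)CCCCCCc1nc(-c2ccccc2)no1`: 730 nM
Compound 3 `Nc1ccccc1NC(=O)CCCCCCc1nc(-c2ccc(Cl)cc2)no1`: 4360 nM

These values come from a functional assay on U-937 cells (Homo sapiens) for antiproliferative activity, read by MTT assay, with a stated time of 72 h; a higher number here means a weaker inhibitor, a lower number a stronger inhibitor. Compound 3 has the highest number of the three, beyond the scatter from both others. Compound 4 `Nc1ccccc1NC(=O)CCCCCCc1nc(-c2cccc([N+](=O)[O-])c2)no1` changes one group of compound 3, with 3-nitrophenyl in place of 4-chlorophenyl on an aromatic carbon. Within the data shown here, one measured step bears on this, since the chloro leaves: a 6.0-fold higher number from compound 2 to compound 3 (0.78 log units; beyond the scatter), a modest step. Compound 1 carries the same 3-nitrophenyl group and gives 1160 nM, though the rest of its structure differs. A moderate step to a lower number is therefore expected in this assay, smaller than the chloro step. The estimate for compound 4 is 1800 nM, with an expected range from 650 nM to 5000 nM. That estimate means a 2.4-fold lower number from compound 3 to compound 4 (0.38 log units; beyond the scatter).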

Compound 4, half-maximal inhibitory concentration: 2150 nM
Compound 4: the middle estimate sits 1.2-fold (0.08 log units) below what was measured; low and high end bracket the measured number.
By their numbers in this assay, from the lowest: compounds 2, 1 and 4 (each within the scatter of the next, the first and the last beyond it); then compound 3.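

In this assay the step of a 2.0-fold lower number from compound 3 to compound 4 (0.31 log units; beyond the scatter) shows that this position tolerates more than one substituted phenyl, yet the step of a 2.9-fold higher number from compound 2 to compound 4 (0.47 log units; beyond the scatter) leaves 3-nitrophenyl short of the plain phenyl of compound 2. So both substituted rings shown here give higher numbers than the plain phenyl. With 3-nitrophenyl in place, the step of a 1.9-fold higher number from compound 1 to compound 4 (0.27 log units; within the scatter) stays within the scatter, so hydroxy and 2-aminophenyl on the amide-type nitrogen cannot be told apart. From the compounds shown here alone, whether an amine or a carboxylic acid on this phenyl ring would give a lower number remains open. Nothing shown explains these differences.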